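What Replacing the 4-(Dimethylamino)phenyl Group Might Do

This account rests on a few compounds, and the source may have more. Where it says the series, first, only, none or still open, it means among the compounds named here.

Measured in a functional assay on HepG2 cells (Homo sapiens) for cytotoxicity, read by MTT assay, with a stated time of 48 h (a lower number here means a stronger inhibitor, a higher number a weaker inhibitor), are:
Compound 1 `O=C1/C(=C\c2ccccc2)S/C(=N/c2ccccc2)N1Cc1ccncc1` with 25200 nM
Compound 2 `O=C1/C(=C\c2ccc([N+](=O)[O-])cc2)S/C(=N/c2ccccc2)N1Cc1ccncc1` with 18900 nM
Compound 3 `CN(C)c1ccc(/C=C2/S/C(=N/c3ccccc3)N(Cc3ccncc3)C2=O)cc1` with 52600 nM

Compound 3 has the highest number of the three, which makes it the weakest inhibitor here. Compound 4 `COc1cc(/C=C2/S/C(=N/c3ccccc3)N(Cc3ccncc3)C2=O)ccc1O` differs from it by 4-hydroxy-3-methoxyphenyl in place of 4-(dimethylamino)phenyl on a double-bonded chain carbon bound to a double-bonded ring carbon with 4-hydroxy-3-methoxyphenyl in place of 4-(dimethylamino)phenyl on a double-bonded chain carbon bound to a double-bonded ring carbon. The steps of a 2.1-fold higher number from compound 1 to compound 3 (0.32 log units; beyond the scatter) and a 2.8-fold higher number from compound 2 to compound 3 (0.44 log units; beyond the scatter) both bring in dimethylamino on an aromatic carbon and both are modest. Going by the values given here, no measured compound carries hydroxy or methoxy. Going by compound 1 at 25200 nM and compound 2 at 18900 nM which lack dimethylamino, a modest move to a lower number is expected in this assay for this swap. The expected change is a 1.9-fold lower number from compound 3 to compound 4 (0.29 log units; within the scatter) in this estimate. For compound 4 the estimated value is 27000 nM with an expected range from 12000 nM to 55000 nM as the likely span.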

Compound 4, half-maximal inhibitory concentration: 28600 nM
For compound 4 the middle estimate is 1.1-fold (0.03 log units) below the measured one; the measured number falls inside the stated range.
By their numbers in this assay, from the lowest: compounds 2, 1, 4 and 3 (each within the scatter of the next, the first and the last beyond it).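

In this assay, 4-hydroxy-3-methoxyphenyl on this double-bonded chain carbon gives a 1.8-fold lower number from compound 3 to compound 4 (0.26 log units; within the scatter), a 1.5-fold higher number from compound 2 to compound 4 (0.18 log units; within the scatter) and a 1.1-fold higher number from compound 1 to compound 4 (0.05 log units; within the scatter). This oxygen-bearing group therefore cannot be told apart from phenyl, 4-nitrophenyl or 4-(dimethylamino)phenyl, even though compounds 2 and 3 are separated beyond the scatter. Nothing available here explains this result.

The compounds shown leave open what hydroxy and methoxy each do alone on the phenyl ring. They also leave open whether a carboxylic acid at this place would stand apart from these groups.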